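Aryl sulfonamide series: methyl for methoxy on the anilide

The source may hold more compounds than are shown below. What is called first, only, known or untested is meant among the compounds shown, and "the series" means these compounds.

Compound 1 `O=C1NCCN1c1ccc(S(=O)(=O)Nc2cccc(Oc3ccccc3)c2)cc1` and compound 2 `COc1cccc(NS(=O)(=O)c2ccc(N3CCNC3=O)cc2)c1` share the core bearing the cyclic urea and the sulfonamide. In a functional assay on M21 cells (Homo sapiens) for antiproliferative activity, read by sulforhodamine B assay, with a stated time of 48 h (on this read-out higher numbers stand for weaker inhibition and lower numbers for stronger inhibition), compound 1 gives 83 nM and compound 2 gives 65 nM; the step of a 1.3-fold lower number from compound 1 to compound 2 (0.11 log units; within the scatter) lies within the scatter, so the two stand level. Going by the values given here, compound 2 carries the smaller of the two numbers measured so far, but its gap to compound 1 does not pass the scatter.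

Compound 3 `Cc1ccc(NS(=O)(=O)c2ccc(N3CCNC3=O)cc2)cc1` is not yet measured. It differs from compound 2 in one place: 4-methylphenyl in place of 3-methoxyphenyl on a sulfonamide nitrogen. Among the compounds with values here, no measured step bears directly on a swap of one substituted phenyl for another on the sulfonamide nitrogen; the only step on record, a 1.3-fold lower number from compound 1 to compound 2 (0.11 log units; within the scatter), altered the oxygen substituent on that same phenyl and stayed within the scatter. There is thus little ground to expect a step beyond the scatter in this assay in either direction. The expected step is a 1.2-fold higher number from compound 2 to compound 3 (0.09 log units; within the scatter), and compound 3 is estimated at 80 nM, in the range 30 nM to 220 nM.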

Compound 3, half-maximal inhibitory concentration: 260 nM
Compound 3: middle estimate off by 3.3-fold (0.51 log units), on the low side; measured number outside the range, above it.
By their numbers in this assay, from the lowest: compounds 2 and 1 (each within the scatter of the next); then compound 3.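

In this assay, going by these compounds alone, the group on the sulfonamide nitrogen proves able to move the number: the change to 4-methylphenyl gives a 4.0-fold higher number from compound 2 to compound 3 (0.60 log units; beyond the scatter), the first step beyond the scatter, whereas the change on the oxygen, a 1.3-fold lower number from compound 1 to compound 2 (0.11 log units; within the scatter), left the pair level. The swap replaces methoxy with methyl and also changes the numbered place on the phenyl, so the step cannot be assigned to either change alone. Nothing on record accounts for the loss.

The compounds shown leave open whether 3-methylphenyl or 4-methoxyphenyl would stand nearer compound 2 or compound 3, which would separate the two changes. Also open, on these data alone, is how an amine or a carboxylic acid on that phenyl would read.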